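The source may report more compounds than this note shows. Statements on the series, on what has been measured and on what is new or still open speak of the compounds shown alone.

Measured so far in a physicochemical assay for lipophilicity, measured as octanol-water partition; a lower number here means a more polar compound, a higher number a more lipophilic compound: compound 1 `CC(=O)Oc1ccccc1-c1nnc(NC(=O)C/C(C)=N/c2ccc([N+](=O)[O-])cn2)s1` gives 3.56; compound 2 `C/C(CC(=O)Nc1nnc(-c2ccc([N+](=O)[O-])cc2)s1)=N\c1ccccn1` gives 3.63.

Of the two numbers in this assay, compound 2 reads slightly above compound 1, a gap within the scatter, so the two are not separated. Compound 3 `C/C(CC(=O)Nc1nnc(-c2ccc([N+](=O)[O-])cc2)s1)=N\c1ccc([N+](=O)[O-])cn1` differs from compound 2 in one place: nitro in place of hydrogen on an aromatic carbon, two atoms from the ring nitrogen. For the measured compounds named here, no measured pair shows this change, so only a small step, if any, and none clearly beyond the scatter, is expected. Compound 3 is therefore estimated at 3.5, within 3.1 to 3.9, an expected step of a number 0.13 log units lower from compound 2 to compound 3 (within the scatter).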

Compound 3, partition coefficient: 3.54
Estimate against measurement, compound 3: 0.04 log units below, and the stated range covers the measured number.
By their numbers in this assay, from the lowest: compounds 3, 1 and 2 (each within the scatter of the next).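

In this assay, the change from pyridin-2-yl to 5-nitropyridin-2-yl gives a number 0.09 log units lower from compound 2 to compound 3 (within the scatter) and so does not separate the two compounds at this position, two atoms from the ring nitrogen. A second change in one place, 4-nitrophenyl in place of 2-acetoxyphenyl on an aromatic carbon, gives a number 0.02 log units lower from compound 1 to compound 3 (within the scatter) and leaves that pair unseparated as well. Nothing available explains either result.

Going by these compounds, whether an amine or a carboxylic acid at this position would give a step beyond the scatter stays open. So does the reading of a compound carrying a methoxy group in place of the nitro.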